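The source may report more compounds than this note shows. Statements on the series, on what has been measured and on what is new or still open speak of the compounds shown alone.

Compound 1 `Oc1cccc(-c2cc(-c3cccc(F)c3)cc(-c3cccc(O)c3)n2)c1`: 21300 nM
Compound 2 `Oc1ccc(-c2cc(-c3cccc(F)c3)cc(-c3cccc(O)c3)n2)cc1`: 3510 nM
Compound 3 `Oc1cccc(-c2cc(-c3ccc(OC(F)(F)F)cc3)cc(-c3ccccc3O)n2)c1`: 7710 nM

All three compounds were tested in a functional assay on T47D cells (Homo sapiens) for inhibition; on this read-out higher numbers stand for weaker inhibition and lower numbers for stronger inhibition. In this assay compound 1 gives 21300 nM, compound 2 gives 3510 nM, and compound 3 gives 7710 nM. Compound 1 and compound 2 differ in one place only: 4-hydroxyphenyl in place of 3-hydroxyphenyl on an aromatic carbon. This change brought a 6.1-fold lower number from compound 1 to compound 2 (0.78 log units; beyond the scatter). Compound 3 shares the same kind of core, but how its core differs from that of compound 1 is not broken down here; the two values simply show compound 3 giving a lower number than compound 1 and a higher number than compound 2.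

Compound 4 `Oc1ccc(-c2cc(-c3ccc(OC(F)(F)F)cc3)cc(-c3ccccc3O)n2)cc1` has not yet been measured. It differs from compound 3 by 4-hydroxyphenyl in place of 3-hydroxyphenyl on an aromatic carbon. Among the compounds with values here, this is the same kind of change as the one from compound 1 to compound 2, but not the same change: in the earlier pair the place is meta to a 3-fluorophenyl group and meta to a 3-hydroxyphenyl group, whereas in compound 3 it is meta to a 2-hydroxyphenyl group and meta to a large group. With those surroundings not identical, the step expected from compound 3 to compound 4 in this assay is a 3.9-fold lower number from compound 3 to compound 4 (0.59 log units; beyond the scatter), somewhat smaller than the earlier one, and it rests on the step of a 6.1-fold lower number from compound 1 to compound 2 (0.78 log units; beyond the scatter). Compound 4 is thus estimated at 2000 nM, expected to lie between 800 nM and 5000 nM.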

Compound 4, half-maximal inhibitory concentration: > 50000 nM
Compound 4 was reported as a limit; the forecaster's own chance of this, stated with the estimate: 0%; at least 25-fold (1.39 log units) between middle value and limit.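

In this assay compound 4 is reported only as a limit of the assay, > 50000 nM, and not as an exact number. Putting 4-hydroxyphenyl in place of 3-hydroxyphenyl brings an at least 6.4-fold higher number from compound 3 to compound 4 (0.81 log units; beyond the scatter), whereas on the other core the same change brought a 6.1-fold lower number from compound 1 to compound 2 (0.78 log units; beyond the scatter), so in these two pairs the change does not carry over from one core to the other and its direction reverses: the same change on two cores in this assay, a 6.1-fold lower number (0.78 log units; beyond the scatter) from compound 1 to compound 2 and an at least 6.4-fold higher number (0.81 log units; beyond the scatter) from compound 3 to compound 4, at least 39-fold (1.59 log units) apart, beyond the scatter of two such steps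
This shows that the outcome of the change depends on the core it is made on, but it does not show which feature of the core decides the outcome, as the two cores differ in more than one place, and the limit leaves the full size of the new step unknown.

The compounds shown leave open whether the 2-hydroxyphenyl group, the trifluoromethoxy group or the 3-fluorophenyl group accounts for the reversal, as no pair here changes one of these alone. They also leave open how the same swap would behave with an amine or a carboxylic acid in place of the hydroxyl group.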